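The source may report more compounds than this note shows. Statements on the series, on what has been measured and on what is new or still open speak of the compounds shown alone.

Working notes on the series. Of the compounds shown here, two carry numbers so far. Within the data shown here, compound 1 `COc1ccc(/C=C/C(=O)c2ccc(N3CCN(c4ccc(C)cc4C)CC3)cc2)cc1OC` and compound 2 `O=C(/C=C/c1ccccc1)c1ccc(N2CCN(S(=O)(=O)c3ccc4ccccc4c3)CC2)cc1` differ in more than one place, so no single step connects them; in a functional assay on the whole organism (strain Kunming) for inhibition, with Mus musculus as the target, with a stated time of 1 h, at a dose of 40 mg/kg by the oral route (on this read-out higher numbers stand for more inhibition at the one dose given (going by the name of the read-out) and lower numbers for less inhibition), compound 1 gives 48.5% and compound 2 gives 35%. Compound 2 therefore stands lowest of the two numbers, with compound 1 above it by a gap beyond the scatter. Compound 3 `O=C(/C=C/c1ccccc1)c1ccc(N2CCN(S(=O)(=O)c3ccc(C(F)(F)F)cc3)CC2)cc1` is next in line. It differs from compound 2 by 4-(trifluoromethyl)phenyl in place of naphthalen-2-yl on a sulfonyl sulfur. Among the measured compounds shown here, no measured pair isolates a change of this kind, so the size of the step in this assay cannot be read from the series; the working expectation is a step no larger than the scatter, with no clear lean in either direction. Compound 3 is accordingly estimated at 33%, with a range from 15% to 50%. That estimate amounts to an expected step of a number 2 percentage points lower from compound 2 to compound 3 (within the scatter).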

Compound 3, a percentage reported as inhibition, in the whole organism at one dose (the size of the read-out at that dose, not a potency): 47.9%
Beside the measured number, compound 3's estimate is 14.9 percentage points below it; low and high end bracket the measured number.
By their numbers in this assay, from the lowest: compound 2; then compounds 3 and 1 (each within the scatter of the next).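

Among these compounds, on the sulfonyl sulfur, 4-(trifluoromethyl)phenyl in place of naphthalen-2-yl gives, in this assay, a number 12.9 percentage points higher from compound 2 to compound 3 (beyond the scatter), the only single-place step, so the group at this position can move the read-out by more than the scatter. The entering group carries one six-membered aromatic ring of carbon only where the leaving group carries 2, at the same count of heavy atoms, so a second fused ring is not required for inhibition at this dose. No measurement at hand bears on the reason for this step.

From the compounds shown here alone, whether the step follows the trifluoromethyl group or the loss of the second ring stays open; a plain phenyl or a 4-chlorophenyl on the same sulfur would separate the two. Steps involving compound 1 cannot be read, and the effect of a carbonyl in place of the sulfonyl also remains open.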